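Taking one fluorine off the aryl group of compound 3

The source may hold more compounds than are shown below. What is called first, only, known or untested is meant among the compounds shown, and "the series" means these compounds.

In an ADME assay on the whole organism (Mus musculus, strain Swiss Webster) for pharmacokinetics, read by LC-MS, at a dose of 50 mg/kg by the oral route (on this read-out higher numbers stand for higher exposure at the dose given and lower numbers for lower exposure), compound 3 `O=C(Nc1ccc(F)c(-c2nc3ncc(-c4cc(F)cc(F)c4)cc3[nH]2)c1)N1CCCC1` gives 9400 ng.h/mL. Compound 1 `O=C(Nc1ccc(F)c(-c2nc3ncc(-c4cc(F)ccc4F)cc3[nH]2)c1)N1CCCC1` gives 5620 ng.h/mL, and only a 1.7-fold higher number from compound 1 to compound 3 (0.22 log units; within the scatter) separates the two, so they count as level. Compound 2 `O=C(Nc1ccc(F)c(-c2nc3ncc(-c4cncc(F)c4)cc3[nH]2)c1)N1CCCC1` stands apart at 1560 ng.h/mL, with a 3.6-fold lower number from compound 1 to compound 2 (0.56 log units; beyond the scatter) and a 6.0-fold higher number from compound 2 to compound 3 (0.78 log units; beyond the scatter).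

Compound 4 `O=C(Nc1ccc(F)c(-c2nc3ncc(-c4ccccc4F)cc3[nH]2)c1)N1CCCC1` keeps the shared core and changes one group: 2-fluorophenyl in place of 3,5-difluorophenyl on an aromatic carbon. In other words, 2-fluorophenyl takes the place of 3,5-difluorophenyl on an aromatic carbon, and the new group is still a ring of carbon only.

Among the measured compounds shown here, no measured step removes a single fluorine, so the evidence is indirect. The closest guide is a 1.7-fold higher number from compound 1 to compound 3 (0.22 log units; within the scatter), a swap between two groups that both have rings of carbon only. The larger steps, a 3.6-fold lower number from compound 1 to compound 2 (0.56 log units; beyond the scatter) and a 6.0-fold higher number from compound 2 to compound 3 (0.78 log units; beyond the scatter), both involve the group of compound 2, whose ring is not of carbon only, so they bear on this change less directly. A slightly lower number is therefore expected, with an estimated 1.7-fold lower number from compound 3 to compound 4 (0.23 log units; within the scatter). For compound 4 the estimate is 5500 ng.h/mL, within an expected range from 2200 ng.h/mL to 13000 ng.h/mL.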

Compound 4, area under the concentration-time curve: 4870 ng.h/mL
For compound 4 the middle estimate is 1.1-fold (0.05 log units) above the measured one, within the range that was stated.
By their numbers in this assay, from the lowest: compound 2; then compounds 4, 1 and 3 (each within the scatter of the next).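

In this assay, taking a fluorine off the aryl group at this position does not move the number beyond the scatter, whether the starting point is the 3,5-difluorophenyl of compound 3 (a 1.9-fold lower number from compound 3 to compound 4 (0.29 log units; within the scatter)) or the other difluorophenyl group of compound 1 (a 1.2-fold lower number from compound 1 to compound 4 (0.06 log units; within the scatter)). Compound 4 also separates from compound 2 (a 3.1-fold higher number from compound 2 to compound 4 (0.49 log units; beyond the scatter)), and since each carries one fluorine, the fluorine count alone does not set compound 2 apart: compound 4 has a ring of carbon only, whereas the ring of compound 2 is not of carbon only. Nothing measured here explains why the numbers fall as they do.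

On these data alone, all four compounds keep at least one fluorine on the ring at this position, so it remains open whether a plain phenyl ring, or a ring carrying chlorine, a methoxy group or an amine, would stay level with compounds 1, 3 and 4. Also open, as far as these compounds go, is whether this levelness holds at other doses or by other routes, since the numbers here come from one oral dose in one mouse strain.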